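The source may hold more compounds than are shown below. What is called first, only, known or untested is meant among the compounds shown, and "the series" means these compounds.

Measured in a functional assay on HCT-116 cells (Homo sapiens) for cytotoxicity, read by fluorescence, with a stated time of 72 h; on this read-out lower numbers stand for stronger inhibition and higher numbers for weaker inhibition:
- Compound 1 `CSc1nc(NCc2ccc(-c3ccccn3)cc2)c2[nH]nc(C(C)C)c2n1`: 2800 nM
- Compound 2 `CC(C)c1n[nH]c2c(NCc3ccc(-c4ccccn4)cc3)nc(NCCO)nc12`: 27 nM

Of these two compounds, compound 2 has the lower number, 27 nM, so it is the stronger inhibitor in this assay. The next compound, compound 3 `CC(C)c1n[nH]c2c(NCc3ccc(-c4ccccn4)cc3)nc(NCC(N)CO)nc12`, has not yet been measured. It carries 1-amino-2-hydroxyethyl in place of hydroxymethyl on a saturated chain carbon bound to a nitrogen on an aromatic ring. Read one bond further out, 2-hydroxyethyl becomes 2-amino-3-hydroxypropyl.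

For the measured compounds named here, only one measured step bears on this change: a 100-fold lower number from compound 1 to compound 2 (2.02 log units; beyond the scatter). That large step came from placing (2-hydroxyethyl)amino in place of methylsulfanyl on an aromatic carbon, and compound 3 modifies that same chain. However, the step replaced a whole group, so it shows that this spot matters without showing what an added amino group does. Going by the values given here, with no measured example of that addition, neither direction is favoured strongly, and no step beyond the scatter is expected. The estimate amounts to a 1.2-fold lower number from compound 2 to compound 3 (0.09 log units; within the scatter), which is an expected step of modest size. Compound 3 is expected to give about 22 nM, with an estimated range of 6 nM to 80 nM.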

Compound 3, half-maximal inhibitory concentration: 781 nM
Estimate against measurement, compound 3: 36-fold (1.55 log units) below; the measured number lies above the stated range.
By their numbers in this assay, from the lowest: compound 2; then compound 3; then compound 1.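

In this assay, this chain is sensitive to a small addition, not only to the replacement of a whole group: going from 2-hydroxyethyl to 2-amino-3-hydroxypropyl gives a 29-fold higher number from compound 2 to compound 3 (1.46 log units; beyond the scatter). The large gain seen on leaving methylsulfanyl therefore does not carry over to every chain at this place, since the comparison with the original group now shows only a 3.6-fold lower number from compound 1 to compound 3 (0.55 log units; beyond the scatter), much less than a 100-fold lower number from compound 1 to compound 2 (2.02 log units; beyond the scatter) seen for the simpler chain. No measurement here explains why the added branch has such a large effect on the number.

The compounds shown do not separate the contribution of the new amino group from that of the extra carbon, as both enter together in one change. A 2-hydroxypropyl chain, which branches without an amine, a 2-aminoethyl chain, which carries an amine in place of the hydroxyl, and a longer chain such as 3-hydroxypropyl would each help show which part of the change matters most at this place.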